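Aminopyrimidine phenoxy series: cytotoxicity notes before compound 4

The source may report more compounds than this note shows. Statements on the series, on what has been measured and on what is new or still open speak of the compounds shown alone.

Compound 1 `COc1ccccc1Oc1c(N)nc(-c2cccc(Cl)c2)nc1Cl` and compound 2 `COc1ccccc1Oc1c(N)nc(-c2ccc(Cl)cc2)nc1Cl` share one core and differ only by 4-chlorophenyl in place of 3-chlorophenyl on an aromatic carbon. In a functional assay on B16 cells (Mus musculus) for cytotoxicity, read by CCK-8 assay, with a stated time of 24 h (on this read-out lower numbers stand for stronger inhibition and higher numbers for weaker inhibition), compound 1 gives 17900 nM, and compound 2 gives 18800 nM; the step of a 1.1-fold higher number from compound 1 to compound 2 (0.02 log units; within the scatter) lies within the scatter, so the two numbers are not told apart. Compound 3 `COc1ccccc1Oc1c(N)nc(-c2cccc(Cl)c2)nc1OCCO` replaces the chloro of compound 1 with 2-hydroxyethoxy, and in this assay compound 3 gives 5010 nM; the step of a 3.6-fold lower number from compound 1 to compound 3 (0.55 log units; beyond the scatter) is beyond the scatter and leaves compound 3 with the lowest number of the three measured.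

Compound 4 `COc1ccccc1Oc1c(N)nc(-c2ccc(Cl)cc2)nc1OCCO` is not yet measured. It differs from compound 3 by 4-chlorophenyl in place of 3-chlorophenyl on an aromatic carbon, the same kind of change as that from compound 1 to compound 2, but not the same: in compound 3 the change sits meta to a 2-hydroxyethoxy group and para to a 2-methoxyphenoxy group, whereas in compound 1 it sits meta to a chloro group and para to a group of 9 heavy atoms. The two cores differ by 2-hydroxyethoxy in place of chloro on an aromatic carbon.

Among the compounds with values here, only one earlier example of this change exists, so the expectation rests on a single step. The step from compound 3 to compound 4 is expected to be a 1.1-fold higher number from compound 3 to compound 4 (0.05 log units; within the scatter), small, because a 1.1-fold higher number from compound 1 to compound 2 (0.02 log units; within the scatter) was within the scatter. Compound 4 is therefore estimated at 5600 nM in this assay, within a range of 2800 nM to 11500 nM.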

Compound 4, half-maximal inhibitory concentration: 7740 nM
Compound 4: the middle estimate sits 1.4-fold (0.14 log units) below what was measured; the measured number falls inside the stated range.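

In this assay, 4-chlorophenyl in place of 3-chlorophenyl remains a small change on the 2-hydroxyethoxy core, with a 1.5-fold higher number from compound 3 to compound 4 (0.19 log units; within the scatter), and its size agrees with that on the chloro core: the same change on two cores in this assay, a 1.1-fold higher number (0.02 log units; within the scatter) from compound 1 to compound 2 and a 1.5-fold higher number (0.19 log units; within the scatter) from compound 3 to compound 4, 1.5-fold (0.17 log units) apart, within the scatter of two such steps

2-Hydroxyethoxy in place of chloro again gives a lower number with 4-chlorophenyl in the molecule, with a 2.4-fold lower number from compound 2 to compound 4 (0.39 log units; beyond the scatter), and this step agrees with the one seen with 3-chlorophenyl: the same change on two cores in this assay, a 3.6-fold lower number (0.55 log units; beyond the scatter) from compound 1 to compound 3 and a 2.4-fold lower number (0.39 log units; beyond the scatter) from compound 2 to compound 4, 1.5-fold (0.17 log units) apart, within the scatter of two such steps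

Within these four compounds the two changes therefore behave alike on either core, but this rests on two pairs of steps in a single assay, says nothing about why the 2-hydroxyethoxy compounds give the lower numbers, and does not extend to other groups or other cells.

On these data alone, it remains open whether the lower number depends on the terminal hydroxyl or on the chain itself, which a 2-methoxyethoxy group, a 3-hydroxypropoxy chain, a 2-aminoethoxy group or a carboxylic acid at the same place could test. As far as these compounds go, it also remains open whether the small effect of moving the chlorine holds for 2-chlorophenyl, or for a phenyl ring carrying fluoro or methoxy in place of chloro.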